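A 4-chloro-2-fluorophenyl swap and cell toxicity

The compounds below may be only part of what the source reports. "The series", "measured", "known", "first", "only" and "open" are said of these compounds alone.

In an ADME assay on L6 cells (Rattus norvegicus) for cytotoxicity, read by resazurin assay, with a stated time of 72 h (a lower number here means a stronger inhibitor, a higher number a weaker inhibitor), compound 3 (`CN(C)c1ccc(C(O)(c2ccc(C(F)(F)F)cc2)c2cccnc2)cc1`) gives 59100 nM and compound 1 (`N#Cc1ccc(C(O)(c2ccc(C(F)(F)F)cc2)c2cccnc2)c(F)c1`) gives 56100 nM on the same test. The gap between them (a 1.1-fold higher number from compound 1 to compound 3 (0.02 log units; within the scatter)) leaves the two level. Compound 2 (`NC(=O)c1ccc(C(O)(c2ccc(C(F)(F)F)cc2)c2cccnc2)cc1`) gives > 100000 nM which is a limit of the assay and not a number. Its steps (an at least 1.7-fold higher number from compound 1 to compound 2 (0.25 log units; that floor lies within the scatter)) and (an at least 1.6-fold lower number from compound 2 to compound 3 (0.22 log units; that floor lies within the scatter)) therefore give only floors.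

Compound 4 (`OC(c1ccc(C(F)(F)F)cc1)(c1cccnc1)c1ccc(Cl)cc1F`) carries 4-chloro-2-fluorophenyl in place of 4-(dimethylamino)phenyl on a saturated chain carbon bound to two aromatic carbons and an oxygen on a saturated carbon. Compound 1 has 4-cyano-2-fluorophenyl at that same place, so it is the closest guide, and its exchange with the group on compound 3 stayed within the scatter (a 1.1-fold higher number from compound 1 to compound 3 (0.02 log units; within the scatter)). No step beyond the scatter is therefore expected in this assay here. The expected step is a 1.2-fold lower number from compound 3 to compound 4 (0.07 log units; within the scatter) and it should stay within the scatter. For compound 4 the estimate is 50000 nM as the expected value, with an expected range from 22000 nM to 100000 nM around it.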

Compound 4, half-maximal inhibitory concentration: > 100000 nM
Compound 4 gave a limit, no number; the forecaster's own chance of this, stated with the estimate: 15%; middle value at least 2.0-fold (0.30 log units) away from the limit.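

In this assay, within the data shown here, the reading for compound 4, > 100000 nM, is a limit of the assay and not a number. 4-chloro-2-fluorophenyl, the first group here at this place without a nitrogen atom, gives an at least 1.6-fold higher number from compound 3 to compound 4 (0.22 log units; that floor lies within the scatter), and chloro in place of cyano on an aromatic carbon gives an at least 1.7-fold higher number from compound 1 to compound 4 (0.25 log units; that floor lies within the scatter), so neither floor shows a change beyond the scatter, though a rise remains possible. The step between compound 2 and compound 4 cannot be read because both stand at the same ceiling: the limit of > 100000 nM in this assay, at which 2 of the 4 values shown sit.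

From the compounds shown here alone, how far compound 4 lies past that ceiling remains open, and so does whether chloro truly differs from cyano here. The compounds shown also do not tell how a carboxylic acid or a primary amine on an aromatic carbon in place of chloro would read.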